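Adding a Methoxy Group and Cytotoxicity in Macrophage Cells

This account rests on a few compounds, and the source may have more. Where it says the series, first, only, none or still open, it means among the compounds named here.

Measured compounds:
compound 1 `COc1ccc(C(=O)CCc2cccc(OC)c2OC)c(O)c1`: 92.8%
compound 2 `COc1ccc(C(=O)CCc2ccc(OC)cc2OC)c(O)c1`: 83.4%
compound 3 `COc1ccc(CCC(=O)c2ccc(OC)cc2O)cc1`: 88%

In an ADME assay on RAW264.7 cells (Mus musculus) for cytotoxicity, read by MTT assay, with a stated time of 24 h, tested at 10 ug/mL (on this read-out higher numbers stand for a weaker effect at the one concentration tested and lower numbers for a stronger effect), compound 1 gives 92.8%, compound 2 gives 83.4% and compound 3 gives 88%. All three numbers sit close together: compound 2 lies within the scatter of compound 3 and of compound 1 alike, so none of the three can be told apart on this read-out.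

Compound 4 `COc1ccc(C(=O)CCc2ccc(OC)c(OC)c2OC)c(O)c1` has not yet been measured. It differs from compound 2 in one place: methoxy in place of hydrogen on an aromatic carbon.

For the measured compounds named here, only one measured step speaks to this change, and it runs the other way: a number 4.6 percentage points higher from compound 2 to compound 3 (within the scatter). Removing a methoxy group from an aromatic carbon therefore left the read-out unmoved. Going by the values given here, with that as the sole guide, adding a methoxy group is expected to leave the read-out unmoved as well, and the step of a number 0.6 percentage points higher from compound 2 to compound 4 (within the scatter) is estimated to stay within the scatter. For compound 4 in this assay the estimate is 84%, with a range from 72% to 96%.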

Compound 4, a percentage reported as activity, at one concentration (the size of the read-out at that concentration, not a potency): 94%
Compound 4: middle estimate off by 10 percentage points, on the low side; low and high end bracket the measured number.
By their numbers in this assay, from the lowest: compounds 2, 3, 1 and 4 (each within the scatter of the next, the first and the last beyond it).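

Putting a methoxy group in place of hydrogen on an aromatic carbon, ortho to two methoxy groups, gives in this assay a clear result: a number 10.6 percentage points higher from compound 2 to compound 4 (beyond the scatter), the only step among those shown that leaves the usual scatter, and it points towards a weaker effect at the one concentration tested. The same kind of swap at a different place gives a number 1.2 percentage points higher from compound 1 to compound 4 (within the scatter), so only one of the two additions can be read as a real shift, and a single methoxy group does not always register on this read-out. Read the other way, with hydrogen replacing methoxy, the change looks alike on two cores: the same change on two cores in this assay, a number 4.6 percentage points higher (within the scatter) from compound 2 to compound 3 and a number 1.2 percentage points lower (within the scatter) from compound 4 to compound 1, 5.8 percentage points apart, within the scatter of two such steps.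

Still open, as far as these compounds go, is whether the shift belongs to methoxy itself or would follow any group on that aromatic carbon, such as a hydroxyl group, an ethoxy group or an amine. From the compounds shown here alone, each number also describes the size of the effect at a single concentration, so whether these compounds would show a stronger or weaker effect relative to one another at other concentrations remains unknown.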